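Amide nitrogen substituent trimmed to hydrogen in a nitro series

The source may hold more compounds than are shown below. What is called first, only, known or untested is meant among the compounds shown, and "the series" means these compounds.

Of the compounds shown here, three have been measured in a functional assay on the whole organism (muscle tissue) with Rattus norvegicus as the target; on this read-out lower numbers stand for smaller maximal responses and higher numbers for larger maximal responses. Compound 1 `CNC(=O)C1=CC(C)(C)Oc2ccc(C#N)cc21` gives 66.6%, compound 2 `CCCCNC(=O)C1=CC(C)(C)Oc2ccc([N+](=O)[O-])cc21` gives 83.2% and compound 3 `CC1(C)C=C(C(=O)NC2CC2)c2cc([N+](=O)[O-])ccc2O1` gives 78%. Compound 3 stands second highest of the three; compound 2 lies within the scatter of it, while compound 1 lies beyond the scatter below it, though compound 1 differs from compound 3 in two places. Compound 4 `CC1(C)C=C(C(N)=O)c2cc([N+](=O)[O-])ccc2O1` differs from compound 3 by hydrogen in place of cyclopropyl on an amide-type nitrogen. For the measured compounds named here, the one step that bears on this is a number 5.2 percentage points lower from compound 2 to compound 3 (within the scatter), where the group on the amide nitrogen was also reduced in size. A step of similar, small size is therefore expected, leaning slightly downward, as a number 6 percentage points lower from compound 3 to compound 4 (within the scatter). Compound 4 is estimated to give 72%, between 58% and 86%.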

Compound 4, intrinsic activity: the largest response reached, in percent of the reference agonist's: 79.8%
For compound 4 the middle estimate is 7.8 percentage points below the measured one; measured number inside the range.
By their numbers in this assay, from the lowest: compound 1; then compounds 3, 4 and 2 (each within the scatter of the next).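

In this assay the amide-type nitrogen of this nitro series tolerates loss of its substituent: hydrogen in place of cyclopropyl gives no change beyond the scatter (a number 1.8 percentage points higher from compound 3 to compound 4 (within the scatter)), and neither does hydrogen in place of butyl (a number 3.4 percentage points lower from compound 2 to compound 4 (within the scatter)). Across butyl, cyclopropyl and hydrogen, then, the group at this position has no readable effect on the maximal response. Nothing measured here accounts for this.
The compounds shown leave open whether a benzyl group on this nitrogen would fit the same picture, and whether a carboxylic acid in place of the amide would keep the response.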